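Replacing 4-chlorobenzyl with cyclohexyl on the amide nitrogen

The source may hold more compounds than are shown below. What is called first, only, known or untested is meant among the compounds shown, and "the series" means these compounds.

Compound 1 (`N[C@H]1CC[C@H](Nc2c(C(=O)NCc3ccc(Cl)cc3Cl)nc(Br)c3cccnc23)CC1`): 5800 nM
Compound 2 (`N[C@H]1CC[C@H](Nc2c(C(=O)NCc3ccc(Cl)cc3)nc(Br)c3cccnc23)CC1`): 1000 nM

Within the data shown here, in a functional assay on MDA-MB-435 cells (Homo sapiens) for cytotoxicity, read by MTT assay, with a stated time of 72 h (a lower number here means a stronger inhibitor, a higher number a weaker inhibitor), compound 2 has the lower of the two numbers measured so far. Compound 3 (`N[C@H]1CC[C@H](Nc2c(C(=O)NC3CCCCC3)nc(Br)c3cccnc23)CC1`) carries cyclohexyl in place of 4-chlorobenzyl on an amide-type nitrogen. Among the measured compounds shown here, only one measured step touches this group: hydrogen in place of chloro on an aromatic carbon gave a 5.8-fold lower number from compound 1 to compound 2 (0.76 log units; beyond the scatter) and that step was modest but beyond the scatter. For the measured compounds named here, no measured step replaces the whole group, so the direction remains uncertain. In this assay a modest rise is expected (a 2.0-fold higher number from compound 2 to compound 3 (0.30 log units; within the scatter)). Compound 3 is estimated at 2000 nM (range 600 nM to 7000 nM).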

Compound 3, half-maximal inhibitory concentration: > 10000 nM
Compound 3 gave a limit, no number (the forecaster's own chance of this, stated with the estimate: 10%); middle value at least 5.0-fold (0.69 log units) away from the limit.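

In this assay, swapping the aromatic ring of 4-chlorobenzyl for the non-aromatic ring of cyclohexyl on the amide-type nitrogen gives an at least 10-fold higher number from compound 2 to compound 3 (1.00 log units; beyond the scatter), so this position responds to replacing the whole group and not only to its chloro substituents. Against 2,4-dichlorobenzyl, the same kind of swap gives an at least 1.7-fold higher number from compound 1 to compound 3 (0.23 log units; that floor lies within the scatter), and that floor alone separates nothing. Compound 3 gives a limit, not a number: the limit of > 10000 nM in this assay, at which 1 of the 3 values shown sits.

Still open, as far as these compounds go, is whether the loss follows the non-aromatic ring or the missing benzyl carbon. Cyclohexylmethyl on the amide-type nitrogen would separate the two.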